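Bromo in place of cyclohexyl: permeability notes

The compounds below may be only part of what the source reports. "The series", "measured", "known", "first", "only" and "open" are said of these compounds alone.

Of the compounds shown here, two sharing one core have been measured so far in an ADME assay for permeability, using PAMPA, at pH 4; on this read-out lower numbers stand for lower permeability and higher numbers for higher permeability. Compound 1 `Cc1[nH]c2ccccc2c(=O)c1C1CCCCC1` gives 260 10^-6 cm/s, the higher of the two numbers. Compound 2 `Cc1[nH]c2ccccc2c(=O)c1Cc1ccccc1` gives 110 10^-6 cm/s, lower than compound 1 by more than the usual scatter.

Compound 3 `Cc1[nH]c2ccccc2c(=O)c1Br` is not yet measured in this assay. Going from compound 1 to compound 3 puts bromo in place of cyclohexyl on an aromatic carbon. For the measured compounds named here, no measured compound carries bromo, so the data offer no direct precedent. Going by the values given here, the one guide is compound 1 at 260 10^-6 cm/s, the higher of only two numbers, which makes a move downward the expected direction. The estimated change is a 3.3-fold lower number from compound 1 to compound 3 (0.51 log units; beyond the scatter), a step expected to lie beyond the scatter. For compound 3 the expected value is 80 10^-6 cm/s, with an estimated range from 25 10^-6 cm/s to 220 10^-6 cm/s.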

Compound 3, apparent permeability: 8.19 10^-6 cm/s
Beside the measured number, compound 3's estimate is 9.8-fold (0.99 log units) above it; the measured number lies below the stated range.
By their numbers in this assay, from the lowest: compound 3; then compound 2; then compound 1.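

In this assay, this position on the aromatic carbon, two atoms from the ring nitrogen, turns out to be far more sensitive to substitution than compound 1 and compound 2 alone could show: bromo in place of cyclohexyl gives a 32-fold lower number from compound 1 to compound 3 (1.50 log units; beyond the scatter), a large step. Compound 3 is also the first in the series with no ring in this substituent, and its number stands well apart from the two ring-bearing compounds. No measurement on hand explains the size of this drop.

A single step cannot separate the loss of the cyclohexyl ring from the arrival of bromine. Going by these compounds, whether a chloro, ethyl or cyclopropyl group at this position would give a number closer to compound 1 or to compound 3 remains open.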